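Trifluoro-Hydroxyethyl Replaces Hydroxyethyl on the Amide Chain

A few compounds are considered here, and "the series" means these few. Any claim that something is new, unique, unknown or untested is made for them only; others in the source may bear on it.

Compound 1, `CNC(=O)c1nc(Br)c(C(F)(F)F)cc1N`, gives 250 nM in an assay on CHO cells for positive allosteric modulation of Cystic fibrosis transmembrane conductance regulator variant F508del (Homo sapiens), using a membrane potential dye, with a stated time of 30 min, in the presence of a further agent that is not named here; on this read-out higher numbers stand for an effect only at larger amounts of compound and lower numbers for an effect already at smaller amounts.
Compound 2, `Nc1cc(C(F)(F)F)c(Br)nc1C(=O)NCCC(F)(F)F`, gives 40 nM.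
Compound 3, `CC(O)CNC(=O)c1nc(Br)c(C(F)(F)F)cc1N`, gives 70 nM.

Compound 3 stands second highest of the numbers shown: its distance to compound 2, a 1.8-fold higher number from compound 2 to compound 3 (0.24 log units; within the scatter), is within the scatter, whereas the step from compound 1 to it, a 3.6-fold lower number from compound 1 to compound 3 (0.55 log units; beyond the scatter), lies beyond it. Compound 4, `Nc1cc(C(F)(F)F)c(Br)nc1C(=O)NC[C@H](O)C(F)(F)F`, has not been measured yet. It differs from compound 3 in one place: 2,2,2-trifluoro-1-hydroxyethyl in place of 1-hydroxyethyl on a saturated chain carbon bound to an amide-type nitrogen. Going by the values given here, two measured steps bear on this change. Adding 2,2,2-trifluoroethyl to the chain gave a 6.3-fold lower number from compound 1 to compound 2 (0.80 log units; beyond the scatter), and exchanging it for 1-hydroxyethyl gave a 1.8-fold higher number from compound 2 to compound 3 (0.24 log units; within the scatter). Compound 4 unites the features of the chains of compound 2 and compound 3. The expected step in this assay is therefore small, towards a lower number or none beyond the scatter: a 1.6-fold lower number from compound 3 to compound 4 (0.19 log units; within the scatter). The estimated value for compound 4 is 45 nM, with a range from 20 nM to 120 nM.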

Compound 4, half-maximal effective concentration: 23 nM
Beside the measured number, compound 4's estimate is 2.0-fold (0.29 log units) above it, within the range that was stated.
By their numbers in this assay, from the lowest: compounds 4, 2 and 3 (each within the scatter of the next, the first and the last beyond it); then compound 1.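

In this assay, going by these compounds alone, fluorine on the hydroxyl-bearing chain brings a gain that the earlier compounds could only suggest: 2,2,2-trifluoro-1-hydroxyethyl in place of 1-hydroxyethyl gives a 3.0-fold lower number from compound 3 to compound 4 (0.48 log units; beyond the scatter). Hydroxy in place of hydrogen on the fluorinated chain gives a 1.7-fold lower number from compound 2 to compound 4 (0.24 log units; within the scatter), so this position accepts the hydroxy there without a change beyond the scatter. Against the simplest amide in the set, the full chain gives the largest step shown, an 11-fold lower number from compound 1 to compound 4 (1.04 log units; beyond the scatter). Nothing here explains the gain from fluorine. As far as these compounds go, an amine in place of the hydroxy, a longer chain and the mirror-image form of this chain all remain open.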